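The compounds below may be only part of what the source reports. "The series", "measured", "known", "first", "only" and "open" are said of these compounds alone.

Working notes on the series. In a functional assay (aorta) with Rattus norvegicus as the target (a higher number here means that more compound is needed for the effect, a lower number that less compound is needed), compound 1, `CC1(C)CC(NC(=O)Nc2ccccc2)c2cc(Br)ccc2O1`, gives 2300 nM. Compound 2, `Cc1ccccc1NC(=O)NC1CC(C)(C)Oc2ccc(Br)cc21`, is known in this assay only as a limit: it gives > 30000 nM, the upper end of what this assay reports, and so compound 2 stands at the weak edge of the two numbers shown. Within the data shown here, the measured step of an at least 13-fold higher number from compound 1 to compound 2 (1.11 log units; beyond the scatter) is the single piece of evidence on this part of the structure; its size is bounded by the limit of > 30000 nM in this assay, at which 1 of the 2 values shown sits, and may be larger than stated.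

Compound 3, `CC1(C)CC(NC(=O)Nc2ccccc2Cl)c2cc(Br)ccc2O1`, follows from compound 2 by chloro in place of methyl on an aromatic carbon. Among the measured compounds shown here, no measured step swaps one group for another at this position; the only step available concerns placing a group there at all, and it was large and unfavourable. On that basis the step of an at least 1.5-fold lower number from compound 2 to compound 3 (0.17 log units; that floor lies within the scatter) is expected to be small, with compound 3 expected to remain near the weak end. For compound 3 the estimate in this assay is 20000 nM, within a range of 5000 nM to 60000 nM, with a real chance that only a limit is returned.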

Compound 3, half-maximal effective concentration: > 30000 nM
Compound 3 gave a limit, no number; the forecaster's own chance of this, stated with the estimate: 45%; middle value at least 1.5-fold (0.17 log units) away from the limit.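

In this assay, the loss seen with 2-methylphenyl recurs with 2-chlorophenyl: an at least 13-fold higher number from compound 1 to compound 3 (1.11 log units; beyond the scatter). The large loss is therefore no longer tied to methyl alone, as two different single-atom-count groups on an aromatic carbon ortho to a large group both leave compound 1's measurable activity behind, and among the three compounds only compound 1, with hydrogen at this place, gives a readable number. The step from compound 2 to compound 3 cannot be read, so methyl and chloro cannot be ranked against each other, and the size of the loss with either group remains undefined: the limit of > 30000 nM in this assay, at which 2 of the 3 values shown sit.

Open, from the compounds shown here alone, is whether any other group at this place, such as fluoro, methoxy or an amine, returns a number near that of compound 1, which gives 2300 nM. Equally open, going by these compounds, is whether the loss on moving away from hydrogen carries over to a core bearing a nitrile in place of the bromo, as all three compounds share the same bromo-substituted core.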